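A Single Added Methyl on Two Related Cores

The compounds below may be only part of what the source reports. "The series", "measured", "known", "first", "only" and "open" are said of these compounds alone.

Compound 1, `COc1nc2c(c(=O)n(C)c(=O)n2C)n1CCCC(=O)Nc1ccc(C(C)(C)C)cc1`, was tested in an assay on isolated protein for inhibition of high affinity 3',5'-cyclic-AMP phosphodiesterase 7A (Homo sapiens), read by cAMP accumulation, with a stated time of 10 min (a lower number here means a stronger inhibitor, a higher number a weaker inhibitor), and gave 19800 nM. Compound 2, `COc1nc2c(c(=O)n(C)c(=O)n2C)n1CCCC(=O)Nc1ccc(C(C)C)cc1`, is reported in this assay only at a limit, > 200000 nM. The two structures differ by methyl in place of hydrogen on a saturated chain carbon bound to an aromatic carbon and two saturated chain carbons, and this change produced an at least 10-fold lower number from compound 2 to compound 1 (1.00 log units; beyond the scatter).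

Compound 3, `CCOc1nc2c(c(=O)n(C)c(=O)n2C)n1CC(=O)Nc1ccc(C(C)C)cc1`, shares much of the same framework but carries a different core; how its core differs from that of compound 2 is not broken down here. In this assay compound 3 also sits only at a limit, > 200000 nM.

Compound 4, `CCOc1nc2c(c(=O)n(C)c(=O)n2C)n1CC(=O)Nc1ccc(C(C)(C)C)cc1`, has not yet been measured. For the measured compounds named here, it differs from compound 3 by methyl in place of hydrogen on a saturated chain carbon bound to an aromatic carbon and two saturated chain carbons, the same change as the one from compound 2 to compound 1, made at the same place. The measured step was an at least 10-fold lower number from compound 2 to compound 1 (1.00 log units; beyond the scatter), and on that basis the step from compound 3 to compound 4 is expected to be an at least 2.0-fold lower number from compound 3 to compound 4 (0.30 log units; that floor lies within the scatter). Because compound 3 sits at the limit of > 200000 nM in this assay, at which 2 of the 3 values shown sit, the starting point of this expected step is itself not a number, so the expectation is held loosely. Going by the values given here, with only one measured instance of this change to rest on, compound 4 is estimated to come in at 100000 nM, within a range from 20000 nM to 400000 nM, and it may well be reported again as a limit rather than as a number.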

Compound 4, half-maximal inhibitory concentration: > 200000 nM
Compound 4: no number, only a limit; the forecaster's own chance of this, stated with the estimate: 55%; at least 2.0-fold (0.30 log units) between middle value and limit.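

Compound 3 and compound 4 both stand only at a limit in this assay, so the step between these two compounds cannot be read, and its size stays unknown: the limit of > 200000 nM in this assay, at which 3 of the 4 values shown sit.

The compounds shown leave open whether the change from 4-isopropylphenyl to 4-(tert-butyl)phenyl lowers the number at all on the core of compound 3, as it did on the core of compound 2.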